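A few compounds are considered here, and "the series" means these few. Any claim that something is new, unique, unknown or untested is made for them only; others in the source may bear on it.

Three analogues sharing one core have been measured in a functional assay on MCF7 cells (Homo sapiens) for inhibition, read by MTT assay, with a stated time of 48 h; a higher number here means a weaker inhibitor, a lower number a stronger inhibitor:

compound 1 `Brc1ccccc1CSc1nnc(-c2ccncc2)n1-c1ccccc1`: 16100 nM
compound 2 `Clc1cccc(CSc2nnc(-c3ccncc3)n2-c2ccccc2)c1`: 10500 nM
compound 3 `Clc1ccc(CSc2nnc(-c3ccncc3)n2-c2ccccc2)cc1`: 13300 nM

Compound 3 stands second highest of the three numbers; its gap to compound 1 and its gap to compound 2 both fall within the scatter, so no order among the three can be read from these values. The step to compound 4 `O=[N+]([O-])c1ccccc1CSc1nnc(-c2ccncc2)n1-c1ccccc1` is 2-nitrophenyl in place of 4-chlorophenyl on a saturated chain carbon bound to a sulfur. Within the data shown here, no measured compound carries a nitro group, so nothing bears on this change directly. What does bear on it are the three steps in which the aryl group on that same carbon was varied: a 1.5-fold lower number from compound 1 to compound 2 (0.19 log units; within the scatter), a 1.2-fold lower number from compound 1 to compound 3 (0.08 log units; within the scatter) and a 1.3-fold higher number from compound 2 to compound 3 (0.10 log units; within the scatter). All three lie within the scatter. On that record, exchanging the substituent on this aryl ring has not moved this assay beyond the scatter, and no step beyond the scatter is expected here either, in no particular direction. The untested group widens the range but not the expected middle. Compound 4 is therefore expected to give 13000 nM (range 5000 nM to 35000 nM), and the expected step of a 1.0-fold lower number from compound 3 to compound 4 (0.01 log units; within the scatter) stays within the scatter.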

Compound 4, half-maximal inhibitory concentration: > 50000 nM
Compound 4: only a limit was reported (the forecaster's own chance of this, stated with the estimate: 10%); at least 3.8-fold (0.58 log units) between middle value and limit.
By their numbers in this assay, from the lowest: compounds 2, 3 and 1 (each within the scatter of the next). At a limit, above all of these: compound 4.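

Compound 4 is reported in this assay only as a limit, not as a number: the limit of > 50000 nM in this assay, at which 1 of the 4 values shown sits.

Against the three halogen-bearing analogues, 2-nitrophenyl on this saturated chain carbon bound to a sulfur gives an at least 3.7-fold higher number from compound 3 to compound 4 (0.57 log units; beyond the scatter), an at least 4.7-fold higher number from compound 2 to compound 4 (0.67 log units; beyond the scatter) and an at least 3.1-fold higher number from compound 1 to compound 4 (0.49 log units; beyond the scatter), the last being the narrowest change, nitro in place of bromo on an aromatic carbon. The aryl group on this carbon can therefore move this assay beyond the scatter, which the exchanges among the halogen-bearing rings did not show, and compound 4 is the weakest inhibitor of the four.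

Going by these compounds, the full size of these steps stays open, as each is bounded on one side only. Also open, on these data alone, is whether the 2-nitrophenyl result is specific to nitro, or whether an amine, a nitrile or a carboxylic acid on the same ring would behave alike.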